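The compounds below may be only part of what the source reports. "The series", "measured", "known", "first", "only" and "open" are said of these compounds alone.

Measured so far:
compound 1 `CC(C)N1CCn2nc(-c3ccc(Cl)cc3)cc2C1=O`: 31000 nM
compound 2 `CCCCN1CCn2nc(-c3ccc(OC)cc3)cc2C1=O`: 62500 nM

In a functional assay on A549 cells (Homo sapiens) for inhibition, read by MTT assay, with a stated time of 48 h (a higher number here means a weaker inhibitor, a lower number a stronger inhibitor), compound 1 gives 31000 nM and compound 2 gives 62500 nM. Compound 2 carries the highest of the two numbers, but its nearest neighbour, compound 1, sits within the scatter of it, so the two cannot be told apart on these data. Compound 3 `CCCCN1CCn2nc(-c3ccc(Cl)cc3)cc2C1=O` has not yet been measured in this assay. It differs from compound 2 by chloro in place of methoxy on an aromatic carbon. For the measured compounds named here, no measured pair differs in this place alone; compound 1 carries the chloro but differs from compound 3 elsewhere as well, so its value cannot be read as the effect of this swap. Both measured numbers are high and close together, and the step of a 1.6-fold lower number from compound 2 to compound 3 (0.19 log units; within the scatter) is expected to be small, within the scatter, with no clear direction. Compound 3 is therefore expected to give 40000 nM in this assay, with a range from 15000 nM to 110000 nM.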

Compound 3, half-maximal inhibitory concentration: 29800 nM
Beside the measured number, compound 3's estimate is 1.3-fold (0.13 log units) above it; measured number inside the range.
By their numbers in this assay, from the lowest: compounds 3, 1 and 2 (each within the scatter of the next, the first and the last beyond it).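

Chloro in place of methoxy on an aromatic carbon, para to a large group, gives the first single-place reading at this position in this assay: a 2.1-fold lower number from compound 2 to compound 3 (0.32 log units; beyond the scatter) is a modest step, only just beyond the scatter. Butyl in place of isopropyl on the amide-type nitrogen in a ring gives a 1.0-fold lower number from compound 1 to compound 3 (0.02 log units; within the scatter) and lies within the scatter, so with chloro on the aromatic ring these two chains cannot be told apart. Nothing at hand bears on the origin of either step.

The compounds shown leave open how fluoro, a nitrile or an amine at this aromatic carbon would compare with chloro and methoxy. They also leave open whether a longer chain on the nitrogen, or one ending in a carboxylic acid, would separate from butyl and isopropyl.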